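Trifluoromethyl for Trifluoromethoxy: Expected Cytotoxicity of Compound 4

The source may report more compounds than this note shows. Statements on the series, on what has been measured and on what is new or still open speak of the compounds shown alone.

Three compounds have been measured in an ADME assay on HepG2 cells (Homo sapiens) for cytotoxicity, with a stated time of 72 h; on this read-out lower numbers stand for an effect already at smaller amounts and higher numbers for an effect only at larger amounts of compound:

Compound 1 `Cc1cc(NC(=O)Nc2ccc(SC(F)(F)F)cc2)c2ccccc2n1` gives 20000 nM.
Compound 2 `Cc1cc(NC(=O)Nc2ccc(C(C)(C)C)cc2)c2ccccc2n1` gives 17000 nM.
Compound 3 `Cc1cc(NC(=O)Nc2ccc(OC(F)(F)F)cc2)c2ccccc2n1` gives 15000 nM.

Compound 3 shows the lowest of the three numbers, but the gaps to its neighbours are small: a 1.1-fold lower number from compound 2 to compound 3 (0.05 log units; within the scatter) and a 1.3-fold lower number from compound 1 to compound 3 (0.12 log units; within the scatter) both lie within the scatter, so no order among the three can be claimed. The same holds for a 1.2-fold lower number from compound 1 to compound 2 (0.07 log units; within the scatter). All three measured steps exchange one group at the same place on the shared core, and none of them moves the number beyond the scatter.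

Compound 4 `Cc1cc(NC(=O)Nc2ccc(C(F)(F)F)cc2)c2ccccc2n1` is the unmeasured member of the set. It differs from compound 3 in one place: trifluoromethyl in place of trifluoromethoxy on an aromatic carbon. Within the data shown here, no measured pair exchanges exactly these two groups, so the three steps serve only as indirect guides. Since each of them stayed within the scatter, the step of a 1.1-fold higher number from compound 3 to compound 4 (0.05 log units; within the scatter) is expected to be of the same kind, with no direction beyond the scatter. Compound 4 is therefore estimated at 17000 nM, within a range from 8000 nM to 36000 nM in this assay.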

Compound 4, half-maximal effective concentration: 23000 nM
Estimate against measurement, compound 4: 1.4-fold (0.13 log units) below; the range from low to high includes it.
By their numbers in this assay, from the lowest: compounds 3, 2, 1 and 4 (each within the scatter of the next).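

In this assay, trifluoromethyl is a fourth group at this place, on an aromatic carbon para to a large group, and each of its steps stays within the scatter (a 1.5-fold higher number from compound 3 to compound 4 (0.19 log units; within the scatter); a 1.4-fold higher number from compound 2 to compound 4 (0.13 log units; within the scatter); a 1.2-fold higher number from compound 1 to compound 4 (0.06 log units; within the scatter)). The exchange for trifluoromethoxy takes away the oxygen and the one hydrogen-bond acceptor counted for that group, yet the step does not go beyond the scatter, so the four groups shown cannot be ranked here. Nothing available explains why these groups give such similar numbers.

All four groups shown have no hydrogen-bond donor and no net charge, so it stays open whether an amine or a carboxylic acid at this place would give a step beyond the scatter. From the compounds shown here alone, it also stays open whether an exchange elsewhere on the shared core would do so.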